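Chloro for fluoro on the methylated core of compound 3

A few compounds are considered here, and "the series" means these few. Any claim that something is new, unique, unknown or untested is made for them only; others in the source may bear on it.

Compound 1 `O=C(Nc1ccc(Oc2ccnc3[nH]ccc23)c(F)c1)c1cc2cccnc2n(-c2ccc(F)cc2)c1=O` gives 62 nM in a functional assay on A549 cells (Homo sapiens) for antiproliferative activity, read by MTT assay, with a stated time of 72 h; a lower number here means a stronger inhibitor, a higher number a weaker inhibitor. Compound 2 `O=C(Nc1ccc(Oc2ccnc3[nH]ccc23)c(F)c1)c1cc2cccnc2n(-c2ccc(Cl)cc2)c1=O` carries chloro in place of fluoro on an aromatic carbon and gives 110 nM in this assay; the step of a 1.8-fold higher number from compound 1 to compound 2 (0.25 log units; within the scatter) stays within the scatter. Compound 3 `Cn1ccc2c(Oc3ccc(NC(=O)c4cc5cccnc5n(-c5ccc(F)cc5)c4=O)cc3F)ccnc21` differs from compound 1 by methyl in place of hydrogen on an aromatic nitrogen; in this assay compound 3 gives 280 nM, the step of a 4.5-fold higher number from compound 1 to compound 3 (0.65 log units; beyond the scatter) lying beyond the scatter. Compound 4 `Cn1ccc2c(Oc3ccc(NC(=O)c4cc5cccnc5n(-c5ccc(Cl)cc5)c4=O)cc3F)ccnc21` is compound 3 with chloro in place of fluoro on an aromatic carbon, the same change, at the same place, as that between compound 1 and compound 2. No measurement of compound 4 exists yet. The step to compound 4 is expected to resemble the earlier one, a 1.8-fold higher number from compound 3 to compound 4 (0.25 log units; within the scatter), because a 1.8-fold higher number from compound 1 to compound 2 (0.25 log units; within the scatter) was small, and the core of compound 3 is not expected to change this. Compound 4 is therefore estimated at 500 nM, between 250 nM and 1000 nM.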

Compound 4, half-maximal inhibitory concentration: 350 nM
The estimate for compound 4 lay 1.4-fold (0.15 log units) above the measured number, within the range that was stated.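

In this assay, 4-chlorophenyl in place of 4-fluorophenyl on the methylated core gives a 1.3-fold higher number from compound 3 to compound 4 (0.10 log units; within the scatter), and this agrees with the step on the core of compound 1: the same change on two cores in this assay, a 1.8-fold higher number (0.25 log units; within the scatter) from compound 1 to compound 2 and a 1.3-fold higher number (0.10 log units; within the scatter) from compound 3 to compound 4, 1.4-fold (0.15 log units) apart, within the scatter of two such steps. Methyl in place of hydrogen on the aromatic nitrogen also carries across the two aryl groups, giving a 3.2-fold higher number from compound 2 to compound 4 (0.50 log units; beyond the scatter): the same change on two cores in this assay, a 4.5-fold higher number (0.65 log units; beyond the scatter) from compound 1 to compound 3 and a 3.2-fold higher number (0.50 log units; beyond the scatter) from compound 2 to compound 4, 1.4-fold (0.15 log units) apart, within the scatter of two such steps. These four compounds show that both changes transfer within this small set in this one cellular read-out, but they do not show transfer to other cores or other changes.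

The compounds shown leave open how an amine or a methoxy group would behave in place of the halogen. They also leave open whether a longer chain on the aromatic nitrogen would follow the methyl step.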